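Sulfonamide nitrogen substituents on a rat aorta relaxant series

A few compounds are considered here, and "the series" means these few. Any claim that something is new, unique, unknown or untested is made for them only; others in the source may bear on it.

The two measured compounds share one core, which carries a sulfonamide. Compound 1 `CC1(C)C=C(n2ccccc2=O)c2cc(S(N)(=O)=O)ccc2O1` bears the unsubstituted sulfonamide, and in a functional assay on the whole organism (aorta) with Rattus norvegicus as the target (on this read-out lower numbers stand for smaller maximal responses and higher numbers for larger maximal responses), compound 1 gives 77.5%. Compound 2 `CC1(C)C=C(n2ccccc2=O)c2cc(S(=O)(=O)NCc3ccccc3)ccc2O1` carries a benzyl group on the sulfonamide nitrogen, and in this assay compound 2 gives 71.1%. Of the two numbers compound 2 has the lower one, yet the step of a number 6.4 percentage points lower from compound 1 to compound 2 (within the scatter) lies within the scatter, so the two compounds cannot be told apart on this read-out.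

Compound 3 `CN(c1ccccc1)S(=O)(=O)c1ccc2c(c1)C(n1ccccc1=O)=CC(C)(C)O2` has not yet been measured. It differs from compound 2 in that (methyl(phenyl)amino in place of benzylamino on a sulfonyl sulfur). Among the measured compounds shown here, the only measured step that bears on this change is the one at the same sulfonamide nitrogen, a number 6.4 percentage points lower from compound 1 to compound 2 (within the scatter), which was too small to matter. Because a number 6.4 percentage points lower from compound 1 to compound 2 (within the scatter) stayed within the scatter, the step to compound 3 is expected to be a number 0.1 percentage points lower from compound 2 to compound 3 (within the scatter), that is, no change beyond the scatter. In this assay compound 3 is therefore estimated at 71%, with a range from 55% to 85%.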

Compound 3, largest response reached (Emax), in percent of the reference or control that the assay uses: 64.2%
Beside the measured number, compound 3's estimate is 6.8 percentage points above it; low and high end bracket the measured number.
By their numbers in this assay, from the lowest: compounds 3, 2 and 1 (each within the scatter of the next, the first and the last beyond it).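

On the sulfonyl sulfur, methyl(phenyl)amino has the same atoms as benzylamino but lacks its hydrogen-bond donor, and in this assay this exchange gives a number 6.9 percentage points lower from compound 2 to compound 3 (within the scatter) and so cannot be told apart on this read-out. Measured against the plain amino group of compound 1, however, methyl(phenyl)amino gives a number 13.3 percentage points lower from compound 1 to compound 3 (beyond the scatter) and thus provides the first step at this position that clears the scatter, although only modestly, showing that a change on the sulfonamide nitrogen can lower the maximal response, which the benzyl step alone had not shown. No available evidence explains this shift at the sulfonamide nitrogen.

The compounds shown leave open whether the step from compound 1 belongs to the methyl group, to the phenyl group on the nitrogen, or to the two together. Also open, as far as these compounds go, is where a plain methylamino group, a morpholine ring or a longer chain such as phenethylamino on the sulfonyl sulfur would fall in this assay and whether any of them would move the response further.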